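The compounds below may be only part of what the source reports. "The series", "measured", "known", "first", "only" and "open" are said of these compounds alone.

Measured in an ADME assay on L1210 cells (Mus musculus) for cytotoxicity, with a stated time of 48 h; on this read-out lower numbers stand for stronger inhibition and higher numbers for weaker inhibition:
compound 1 `C=C1[C@H](C)CCC[C@]1(C)CC/C(C)=C/CC1=C(O)C(=O)C=C(N[C@@H](C(=O)O)C(C)C)C1=O`, 3.4 ug/mL
compound 2 `C=C1[C@H](C)CCC[C@]1(C)CC/C(C)=C/CC1=C(O)C(=O)C=C(N[C@@H](C(=O)O)[C@H](C)O)C1=O`, 4.6 ug/mL
compound 3 `CC1=CCC[C@](C)(CC/C(C)=C/CC2=C(O)C(=O)C=C(N[C@H](C(=O)O)[C@H](C)O)C2=O)[C@@H]1C`, a limit and not a number, > 10 ug/mL

Compound 4 `CC1=CCC[C@](C)(CC/C(C)=C/CC2=C(O)C(=O)C=C(N[C@H](C(=O)O)C(C)C)C2=O)[C@@H]1C` has not been measured in this assay. From compound 2 to compound 1 the change is isopropyl in place of 1-hydroxyethyl on a saturated chain carbon bound to an amine nitrogen and a carbonyl carbon, and the step is a 1.4-fold lower number from compound 2 to compound 1 (0.13 log units; within the scatter). The same change, (isopropyl in place of 1-hydroxyethyl on a saturated chain carbon bound to an amine nitrogen and a carbonyl carbon), leads from compound 3 to compound 4, at a place described in the same words. How the core of compound 2 differs from the core of compound 3 is not broken down here. For compound 3 this assay reports only a limit, (the limit of > 10 ug/mL in this assay, at which 1 of the 3 values shown sits). Compound 4 is expected to give 12 ug/mL, within 5 ug/mL to 40 ug/mL. For compound 4 the expected step that the limit leaves unreadable from compound 3 to compound 4 rests on the measured step of a 1.4-fold lower number from compound 2 to compound 1 (0.13 log units; within the scatter) lying within the scatter, so a value near the limit is expected again.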

Compound 4, half-maximal inhibitory concentration: 3.4 ug/mL
Compound 4: middle estimate off by 3.5-fold (0.55 log units), on the high side; measured number below the stated range.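

In this assay, on the core of the later pair, isopropyl in place of 1-hydroxyethyl gives an at least 2.9-fold lower number from compound 3 to compound 4 (0.46 log units; beyond the scatter). Whether this differs from the same change on the other core is not settled: the same change on two cores in this assay, a 1.4-fold lower number (0.13 log units; within the scatter) from compound 2 to compound 1 and an at least 2.9-fold lower number (0.46 log units; beyond the scatter) from compound 3 to compound 4; the limit leaves it open whether they differ
For compound 3, > 10 ug/mL is a limit and not a number.

Open, as far as these compounds go, is what other groups would give at this place, on a saturated chain carbon bound to an amine nitrogen and a carbonyl carbon, for example a benzyl group or a longer chain ending in an amine. Going by these compounds alone, also open is how far the two cores differ in their own right, since no step between them is read here.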